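A Bromo Group Enters the Phenyl Ring of Compound 1

This account rests on a few compounds, and the source may have more. Where it says the series, first, only, none or still open, it means among the compounds named here.

Compound 1 `C/C(=N\NC(=O)/C(C#N)=C/c1ccccc1)c1c(O)c2ccc(O)cc2oc1=O` was tested in a functional assay on SK-N-SH cells (Homo sapiens) for cytotoxicity, read by MTT assay, with a stated time of 24 h (on this read-out higher numbers stand for weaker inhibition and lower numbers for stronger inhibition), where compound 1 gives 13500 nM. Among the measured compounds shown here, of the two numbers measured so far this is the highest; the other belongs to compound 2 `C/C(=N\NC(=O)/C(C#N)=C/c1ccccc1[N+](=O)[O-])c1c(O)c2ccc(O)cc2oc1=O`, which in this assay gives 12300 nM. For the measured compounds named here, the single step that can be traced, a 1.1-fold lower number from compound 1 to compound 2 (0.04 log units; within the scatter), changes nothing beyond the scatter. Compound 3 `C/C(=N\NC(=O)/C(C#N)=C/c1cccc(Br)c1)c1c(O)c2ccc(O)cc2oc1=O` differs from compound 1 by bromo in place of hydrogen on an aromatic carbon, sitting on an aromatic carbon of a six-membered aromatic ring of carbon only, meta to a large group. Going by the values given here, no measured step swaps hydrogen for bromo; the only guide is the step to compound 2, where a different group entered the same six-membered aromatic ring of carbon only and left the number within the scatter. On that guide the step of a 1.1-fold lower number from compound 1 to compound 3 (0.05 log units; within the scatter) is expected to be small, with no clear direction. Compound 3 is therefore estimated at 12000 nM, within a range from 5000 nM to 30000 nM.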

Compound 3, half-maximal inhibitory concentration: 31300 nM
The estimate for compound 3 lay 2.6-fold (0.42 log units) below the measured number; measured number outside the range, above it.
By their numbers in this assay, from the lowest: compounds 2 and 1 (each within the scatter of the next); then compound 3.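

The step from phenyl to 3-bromophenyl, with the bromo meta to a large group, gives a 2.3-fold higher number from compound 1 to compound 3 (0.37 log units; beyond the scatter) in this assay and is the first change to this phenyl ring shown to move the number beyond the scatter, here toward weaker inhibition. The swap of 2-nitrophenyl for 3-bromophenyl points the same way, with a 2.5-fold higher number from compound 2 to compound 3 (0.41 log units; beyond the scatter) on this read-out, so changes to this ring do not all leave the number where it was. Nothing available here says why the number rose.

The compounds shown leave open whether the higher number belongs to bromo itself or to its place on the ring. They also leave open whether chloro, methoxy or an amine on this same carbon would move the number in the same direction.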